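The source may hold more compounds than are shown below. What is called first, only, known or untested is meant among the compounds shown, and "the series" means these compounds.

Measured compounds:
compound 1, `COC(=O)/C=C/c1cccc(N(Cc2ccc(/C=C/c3c(F)cccc3F)cc2)C(=O)C(C)C)c1` — 108 nM
compound 2, `COC(=O)/C=C/c1ccc(CN(C(=O)C2CCCCC2)c2cccc(/C=C/C(=O)OC)c2)cc1` — a limit of > 1000 nM

In an assay on isolated protein with Bile acid receptor (Homo sapiens) as the target (on this read-out higher numbers stand for an effect only at larger amounts of compound and lower numbers for an effect already at smaller amounts), compound 1 gives 108 nM. For compound 2 the result in this assay is only a limit, > 1000 nM, and not a number. Within the data shown here, compound 1 therefore stands as the only numeric value in this set, while the other entry sits at the limit of > 1000 nM in this assay, at which 1 of the 2 values shown sits. Compound 3, `COC(=O)/C=C/c1cccc(N(Cc2ccc(/C=C/c3cccc(Cl)c3)cc2)C(=O)C(C)C)c1`, has not yet been measured. It differs from compound 1 in one place: 3-chlorophenyl in place of 2,6-difluorophenyl on a double-bonded chain carbon bound to a double-bonded chain carbon. Among the measured compounds shown here, no step between two measured compounds is available to guide the size of this change, so the expectation rests on compound 1 alone. In this assay a modest step towards weaker binding, or none beyond the usual scatter, is expected. Compound 3 is expected to give 180 nM, within a range from 60 nM to 600 nM. This expectation corresponds to a step of a 1.7-fold higher number from compound 1 to compound 3 (0.22 log units; within the scatter).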

Compound 3, half-maximal effective concentration: 164 nM
Estimate against measurement, compound 3: 1.1-fold (0.04 log units) above, and the stated range covers the measured number.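

Until now, the group at this place had been seen only as the 2,6-difluorophenyl of compound 1, so nothing showed how much the read-out depended on it. In this assay, replacing it with 3-chlorophenyl on a double-bonded chain carbon bound to a double-bonded chain carbon gives a 1.5-fold higher number from compound 1 to compound 3 (0.18 log units; within the scatter), so this exchange, in which both fluorine atoms leave and one chlorine atom enters, produces no change beyond the scatter. No measurement shown here bears on the reason for this result.

Among these compounds, the single exchange does not separate the loss of fluorine from the entry of chlorine, and a plain phenyl would be needed to tell these apart. From the compounds shown here alone, whether a ring carrying an amine or a carboxylic acid would be accepted at this place also remains open.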